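Selenium for sulfur in a diacylated isothiourea series

A few compounds are considered here, and "the series" means these few. Any claim that something is new, unique, unknown or untested is made for them only; others in the source may bear on it.

Measured compounds:
Compound 1, `C[Se]/C(=N\C(=O)c1cccs1)NC(=O)c1cccs1`: 3.4 nM
Compound 2, `CS/C(=N\C(=O)c1cccs1)NC(=O)c1cccs1`: 44500 nM
Compound 3, `CS/C(=N\C(=O)c1cc(-c2ccccc2)nc2ccccc12)NC(=O)c1cc(-c2ccccc2)nc2ccccc12`: 43100 nM

Of the compounds shown here, three have been tested in a functional assay on MCF7 cells (Homo sapiens) for cytotoxicity, read by MTT assay, with a stated time of 72 h; a higher number here means a weaker inhibitor of growth, a lower number a stronger inhibitor of growth. Compound 1 and compound 2 share one core; compound 3 carries a different core, and the difference between the two cores is not broken down here. In this assay compound 2 gives 44500 nM and compound 3 gives 43100 nM, two values within the usual scatter of each other.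

Among the compounds with values here, the one change that has been measured is a group of 2 heavy atoms (1 carbon, 1 selenium; no ring) in place of a group of 2 heavy atoms (1 carbon, 1 sulfur; no ring), on a carbon with a double bond to nitrogen. It made a 13000-fold lower number from compound 2 to compound 1 (4.12 log units; beyond the scatter), a very large step.

Compound 4, `C[Se]/C(=N\C(=O)c1cc(-c2ccccc2)nc2ccccc12)NC(=O)c1cc(-c2ccccc2)nc2ccccc12`, has not been measured. It is obtained from compound 3 by the same change, (a group of 2 heavy atoms (1 carbon, 1 selenium; no ring) in place of a group of 2 heavy atoms (1 carbon, 1 sulfur; no ring), on a carbon with a double bond to nitrogen), on the same kind of carbon. Compound 3 starts from the same place as compound 2: compound 3 gives 43100 nM and compound 2 gives 44500 nM. The step is therefore expected to be of similar size, a 5400-fold lower number from compound 3 to compound 4 (3.73 log units; beyond the scatter), though it rests on a single measured pair and a different core may not carry it fully. Compound 4 is therefore estimated at 8 nM, likely between 1.5 nM and 150 nM.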

Compound 4, concentration for 50% growth inhibition: 490 nM
The estimate for compound 4 lay 61-fold (1.79 log units) below the measured number, and the stated range ends below it.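

In this assay, putting the selenium group in place of methylsulfanyl on the second core gave an 88-fold lower number from compound 3 to compound 4 (1.94 log units; beyond the scatter), so the direction of the change carried over and the selenium compound again had the lower number. The size of the step did not carry over, and a large effect seen on one core therefore cannot simply be copied onto another in this series: the same change on two cores in this assay, a 13000-fold lower number (4.12 log units; beyond the scatter) from compound 2 to compound 1 and an 88-fold lower number (1.94 log units; beyond the scatter) from compound 3 to compound 4, 150-fold (2.17 log units) apart, beyond the scatter of two such steps. Within the data shown here, with only two cores, this pair of steps does not show which part of the cores sets the gap, nor how large the step would be on a third core.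

The compounds shown leave open whether a core lying structurally between these two would give a step of intermediate size. Also open, from the compounds shown here alone, is what a longer chain such as ethyl on the selenium, or an amine on the same carbon in place of the selenium group, would do to growth inhibition in this assay.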